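The compounds below may be only part of what the source reports. "The series", "measured", "known", "first", "only" and "open" are said of these compounds alone.

Measured compounds:
- compound 1 `OC1CCCN(c2nc(-c3ccccn3)nc3c2CN(Cc2ccccc2)CC3)C1`: 30.6%
- compound 2 `CN1CCN(CCCNc2nc(-c3ccccn3)nc3c2CN(Cc2ccccc2)CC3)CC1`: "not active" (no number reported)

In an assay on A549 cells with Cystic fibrosis transmembrane conductance regulator variant F508del (Homo sapiens) as the target, read by fluorescence, with a stated time of 25 min (on this read-out lower numbers stand for smaller maximal responses and higher numbers for larger maximal responses), compound 1 gives 30.6%, a moderate maximal response. In this assay compound 2 is reported as "not active" (no number reported), so no number stands beside it and it can only be placed as giving no measurable response. Among the compounds with values here, the two measured compounds differ in more than one place, so no single step between them is worked out, and what they show is only that a compound of this shared core can reach a moderate response or none at all.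

Compound 3 `CN(C)CCN1CCN(c2nc(-c3ccccn3)nc3c2CN(Cc2ccccc2)CC3)CC1` is not yet measured. It differs from compound 2 in one place: 4-(2-(dimethylamino)ethyl)piperazin-1-yl in place of (3-(4-methylpiperazin-1-yl)propyl)amino on an aromatic carbon. The group that enters is joined to the core through a ring nitrogen, as the group in compound 1 is, while the group that leaves hangs on a chain through a nitrogen bearing a hydrogen. Because compound 2 is "not active" (no number reported), any change in this assay can only go upward or stay within the scatter; a small to moderate upward step is expected here. Compound 3 is estimated to give 20% in this assay, within a range of 0% to 40%.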

Compound 3, largest response reached (Emax), in percent of the reference or control that the assay uses: 57%
Estimate against measurement, compound 3: 37 percentage points below, and the stated range ends below it.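

In this assay compound 2 is reported as "not active" (no number reported), while compound 3 gives 57%, so at this aromatic carbon the way the same atoms are joined, and not just which atoms are present, separates a compound without a number from one with a clear maximal response. Among the groups attached through a ring nitrogen, putting 4-(2-(dimethylamino)ethyl)piperazin-1-yl in place of 3-hydroxypiperidin-1-yl gives a number 26.4 percentage points higher from compound 1 to compound 3 (beyond the scatter), which shows that the response at this position also depends on which ring-linked group is present. No measurement given here explains why either change alters the response.

The compounds shown leave open how much of the 4-(2-(dimethylamino)ethyl)piperazin-1-yl group is needed, since a simpler 4-methylpiperazin-1-yl group or a longer 4-(3-(dimethylamino)propyl)piperazin-1-yl group would test the role of the side chain on the piperazine ring. They also leave open whether a morpholin-4-yl group, with oxygen in the ring in place of the second nitrogen, would keep a response of this size in this assay.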